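Cytotoxicity in the thienyl amide series: towards compound 4

A few compounds are considered here, and "the series" means these few. Any claim that something is new, unique, unknown or untested is made for them only; others in the source may bear on it.

Compound 1 `CC(C)n1ncc2c(C(=O)Nc3ccc(F)cc3)cc(-c3cccs3)nc21` reaches only the limit of > 200000 nM in an ADME assay on LLC-MK2 cells (Macaca mulatta) for cytotoxicity, read by spectrophotometry and crystal violet staining, with a stated time of 4 days; on this read-out lower numbers stand for higher toxicity in this test and higher numbers for lower toxicity in this test; this is a limit, not a number. Compound 2 `CC(C)n1ncc2c(C(=O)Nc3ncccn3)cc(-c3ccsc3)nc21` gives 50000 nM in this assay. Within the data shown here, compound 3 `CC(C)n1ncc2c(C(=O)Nc3ncccn3)cc(-c3cccs3)nc21` gives 75000 nM in this assay, the highest of the two numbers, the only other number sitting a step of a 1.5-fold higher number from compound 2 to compound 3 (0.18 log units; within the scatter) off. Compound 4 `CC(C)n1ncc2c(C(=O)Nc3ccc(F)cc3F)cc(-c3cccs3)nc21` carries 2,4-difluorophenyl in place of pyrimidin-2-yl on an amide-type nitrogen. The step that bears on it runs the other way, an at least 2.6-fold lower number from compound 1 to compound 3 (0.42 log units; beyond the scatter), at the same amide-type nitrogen. Returning from pyrimidin-2-yl to a fluorinated phenyl should therefore raise the number in this assay by at least a modest step, and a return to the limit of > 200000 nM in this assay, at which 1 of the 3 values shown sits, is possible. Compound 4 is expected to give 200000 nM, range 80000 nM to 500000 nM, an expected step of a 2.7-fold higher number from compound 3 to compound 4 (0.43 log units; beyond the scatter).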

Compound 4, half-maximal cytotoxic concentration: > 200000 nM
Compound 4: no number, only a limit; the forecaster's own chance of this, stated with the estimate: 55%; the middle value sits exactly at the limit.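

Placing 2,4-difluorophenyl in place of pyrimidin-2-yl on the amide-type nitrogen gives an at least 2.6-fold higher number from compound 3 to compound 4 (0.42 log units; beyond the scatter) in this assay, so the change is now seen with two fluorinated phenyl groups rather than with 4-fluorophenyl alone. Compound 4 sits at a limit, not a number, and it shares that limit with another compound: the limit of > 200000 nM in this assay, at which 2 of the 4 values shown sit. The fluoro difference between compound 1 and compound 4 cannot be read between two limits.

On these data alone, what an amine or a carboxylic acid on the phenyl group would give in this assay stays open. So does the effect of 2,4-difluorophenyl when thiophen-3-yl replaces thiophen-2-yl.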